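Benzyl replacing the ester chain on the shared core

The source may report more compounds than this note shows. Statements on the series, on what has been measured and on what is new or still open speak of the compounds shown alone.

In a functional assay on A549 cells (Homo sapiens) for inhibition, read by sulforhodamine B assay, with a stated time of 48 h (on this read-out lower numbers stand for stronger inhibition and higher numbers for weaker inhibition), compound 2 (`CCOC(=O)C(C)C(O)(c1ccc(OC)c(OC)c1OC)c1cccc2ccccc12`) gives 4000 nM and compound 1 (`COc1ccc(C(O)(Cc2ccc(F)cc2)c2cccc3ccccc23)c(OC)c1OC`) gives 5940 nM, so the two stand level within the scatter. Compound 3 (`COc1ccc(C(O)(Cc2ccccc2)c2cccc3ccccc23)c(OC)c1OC`) differs from compound 2 as follows: benzyl in place of 1-(ethoxycarbonyl)ethyl on a saturated chain carbon bound to two aromatic carbons and an oxygen on a saturated carbon. For the measured compounds named here, the one measured step bearing on this is a 1.5-fold lower number from compound 1 to compound 2 (0.17 log units; within the scatter). It starts from 4-fluorobenzyl, the group closest to the entering benzyl. A similarly small rise, or none beyond the scatter, is therefore expected, and the estimated step is a 1.4-fold higher number from compound 2 to compound 3 (0.14 log units; within the scatter). For compound 3 the expected value is 5500 nM, with an estimated range of 2500 nM to 12000 nM.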

Compound 3, half-maximal inhibitory concentration: > 20000 nM
Compound 3 gave a limit, no number (the forecaster's own chance of this, stated with the estimate: 5%); middle value at least 3.6-fold (0.56 log units) from the limit.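

Compound 3 is recorded only as a limit: the limit of > 20000 nM in this assay, at which 1 of the 3 values shown sits.

Benzyl in place of 1-(ethoxycarbonyl)ethyl on this saturated chain carbon gives an at least 5.0-fold higher number from compound 2 to compound 3 (0.69 log units; beyond the scatter), so this position is not indifferent to the group it carries, although compounds 1 and 2 stood level within the scatter. Hydrogen in place of fluoro on an aromatic carbon gives an at least 3.3-fold higher number from compound 1 to compound 3 (0.52 log units; beyond the scatter), so the fluoro separates two otherwise identical compounds.

As far as these compounds go, the full size of both steps stays open. Also open, from the compounds shown here alone, is how chloro on that aromatic carbon, or a carboxylic acid or an amine in place of the ester chain, would read.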